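A few compounds are considered here, and "the series" means these few. Any claim that something is new, unique, unknown or untested is made for them only; others in the source may bear on it.

Measured in a functional assay on KB cells (Homo sapiens) for antiproliferative activity, read by sulforhodamine B assay, with a stated time of 3 days; a higher number here means that more compound is needed for the effect, a lower number that less compound is needed:

- compound 1 `CCC1=C(O)c2c(oc(-c3ccccc3)cc2=O)C(CC)(CC)C1=O`: > 236 uM, a limit of the assay and not a number
- compound 2 `CCC1=C(O)c2c(oc(-c3ccc(C)cc3)cc2=O)C(CC)(CC)C1=O`: 39.2 uM
- compound 3 `CCC1=C(O)c2c(oc(-c3ccc(CC)cc3)cc2=O)C(CC)(CC)C1=O`: 21.9 uM

Only compound 2 and compound 3 give real numbers, and those two numbers cannot be told apart: a 1.8-fold lower number from compound 2 to compound 3 (0.25 log units; within the scatter). Compound 1 offers only (the limit of > 236 uM in this assay, at which 1 of the 3 values shown sits), so the steps that start from it give a minimum size and not an exact one.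

Compound 4 `CCCc1ccc(-c2cc(=O)c3c(o2)C(CC)(CC)C(=O)C(CC)=C3O)cc1` extends the chain of compound 3: methyl in place of hydrogen on a saturated chain carbon, two bonds along the chain from an aromatic carbon. This places methyl in place of hydrogen on a saturated chain carbon, two bonds along the chain from an aromatic carbon, turning 4-ethylphenyl into 4-propylphenyl.

The closest guide is the previous chain extension, from methyl to ethyl: a 1.8-fold lower number from compound 2 to compound 3 (0.25 log units; within the scatter). The larger steps, an at least 6.0-fold lower number from compound 1 to compound 2 (0.77 log units; beyond the scatter) and an at least 10-fold lower number from compound 1 to compound 3 (1.03 log units; beyond the scatter), put a group on an aromatic carbon. That is a different change, so they say less here. No step beyond the scatter is therefore expected in this assay, though a slightly lower number would continue the small drift. The estimate means a 1.4-fold lower number from compound 3 to compound 4 (0.14 log units; within the scatter), which is an expected step and not a measured one. For compound 4 the expected value is 16 uM, with an estimated range from 6 uM to 45 uM.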

Compound 4, concentration for half-maximal effect: > 53 uM
Compound 4: no number, only a limit (the forecaster's own chance of this, stated with the estimate: 7%); middle value at least 3.3-fold (0.52 log units) from the limit.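

Going from 4-ethylphenyl to 4-propylphenyl breaks with what the methyl and ethyl compounds suggested, since those two could not be told apart, whereas this one added carbon gives an at least 2.4-fold higher number from compound 3 to compound 4 (0.38 log units; beyond the scatter). Set against the methyl compound, the same chain gives an at least 1.3-fold higher number from compound 2 to compound 4 (0.13 log units; that floor lies within the scatter), so the propyl compound is separated from the ethyl compound but not, on this floor, from the methyl compound. In this assay, compound 4 gives only a limit and not a number, and the step between compound 1 and compound 4 cannot be read: the limit of > 53 uM in this assay, at which 1 of the 4 values shown sits.

The compounds shown leave open the real value of compound 4, and with it the full size of the step that one added carbon causes at this place on the chain. They also leave open what a butyl chain or a branched isopropyl group would do in place of propyl, and whether a chain ending in an amine or a carboxylic acid would give a lower or a higher number than the plain ethyl chain of compound 3.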